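The source may hold more compounds than are shown below. What is called first, only, known or untested is meant among the compounds shown, and "the series" means these compounds.

Measured compounds:

compound 1, `COc1cc(/C=C2\CN(C)C/C(=C\c3ccc(Br)cc3)C2=O)cc(OC)c1`, 21300 nM
compound 2, `COc1cc(/C=C2\CN(C)C/C(=C\c3ccc(Cl)cc3Cl)C2=O)cc(OC)c1`, 18800 nM
compound 3, `CN1C/C(=C\c2ccc(Br)cc2)C(=O)/C(=C/c2ccc(C#N)cc2)C1`, 10500 nM

All three were run in an ADME assay on L02 cells (Homo sapiens) for cytotoxicity, read by MTT assay, with a stated time of 24 h; on this read-out lower numbers stand for stronger inhibition and higher numbers for weaker inhibition. Compound 1 and compound 2 share one core and differ in a single place: 2,4-dichlorophenyl in place of 4-bromophenyl on a double-bonded chain carbon bound to a double-bonded ring carbon. This change gave a 1.1-fold lower number from compound 1 to compound 2 (0.05 log units; within the scatter), so compound 1 and compound 2 are not separated in this assay. Compound 3 has a different core, and the difference between the two cores is not broken down here. Compound 3 gives the lowest number of the three; against compound 2 the gap is within the scatter, against compound 1 it is beyond the scatter, so compound 3 can only be set apart from compound 1, not from compound 2.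

Compound 4, `CN1C/C(=C\c2ccc(C#N)cc2)C(=O)/C(=C/c2ccc(Cl)cc2Cl)C1`, is not yet measured. It stands to compound 3 as compound 2 stands to compound 1: 2,4-dichlorophenyl in place of 4-bromophenyl on a double-bonded chain carbon bound to a double-bonded ring carbon. The place is the same in both pairs, so this is the same change on the two cores. On the core of compound 1 the change moved the number little, and the only basis for an expectation is that one step. Compound 4 is therefore expected to sit close to compound 3, with an estimated step of a 1.1-fold lower number from compound 3 to compound 4 (0.04 log units; within the scatter), because a 1.1-fold lower number from compound 1 to compound 2 (0.05 log units; within the scatter) was within the scatter. Compound 4 is expected to give about 9500 nM. The expected range for compound 4 runs from 4500 nM to 20000 nM.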

Compound 4, half-maximal inhibitory concentration: 10800 nM
The estimate for compound 4 lay 1.1-fold (0.06 log units) below the measured number, and the stated range covers the measured number.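

In this assay, 2,4-dichlorophenyl in place of 4-bromophenyl on a double-bonded chain carbon bound to a double-bonded ring carbon gave a 1.0-fold higher number from compound 3 to compound 4 (0.01 log units; within the scatter), so this change does not separate the two compounds on this core. Set beside the earlier step, the result on the second core does not differ from that on the first: the same change on two cores in this assay, a 1.1-fold lower number (0.05 log units; within the scatter) from compound 1 to compound 2 and a 1.0-fold higher number (0.01 log units; within the scatter) from compound 3 to compound 4, 1.2-fold (0.07 log units) apart, within the scatter of two such steps. Within the data shown here, this shows that the swap leaves the number unmoved, within the scatter, on both cores in this assay; it does not show that the two groups are interchangeable on a third core or in another test, it cannot exclude a small real effect hidden in the scatter, and, with only two pairs, both with little movement, it does not show that a change with a large effect would carry from one core to another in the same way.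

The compounds shown leave open how the number responds when this place holds something other than a halogen-bearing phenyl, such as a phenyl carrying an amine or a carboxylic acid, or a longer chain. They also leave open whether the nitrile-bearing phenyl on the other side of compound 3 and compound 4 contributes to where these two compounds stand in this assay.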